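This account rests on a few compounds, and the source may have more. Where it says the series, first, only, none or still open, it means among the compounds named here.

Among the measured compounds shown here, compound 3 `O=C(O)CC[C@H](NC(=O)CN(c1nc(Cl)nc2[nH]cnc12)C1CC1)C(=O)O` stands, among the three compounds measured so far, at the top in a functional assay on the whole organism (Tail, strain ICR) with Mus musculus as the target, in the tail flick test, with a stated time of 150 min, at a dose of 25 umol/kg by the oral route; a higher number here means a stronger effect of the compound at the dose given, a lower number a weaker effect: compound 3 gives 29.5%. Compound 2 `O=C(CN(c1nc(Cl)nc2[nH]cnc12)C1CC1)NCC(=O)OCc1ccccc1` gives 18% in this assay, and compound 1 `NCCCC[C@H](NC(=O)CN(c1nc(Cl)nc2[nH]cnc12)C1CC1)C(=O)OCc1ccccc1` gives 9.88%. The gap from compound 3 to compound 2 lies beyond the scatter, and the gap from compound 3 to compound 1 lies beyond the scatter as well; compound 3 is thus the most active of the three. Compound 4 `CC(C)C[C@H](NC(=O)CN(c1nc(Cl)nc2[nH]cnc12)C1CC1)C(=O)O` differs from compound 3 in one place: isopropyl in place of carboxymethyl on a saturated chain carbon, two bonds along the chain from an amide-type nitrogen and a carbonyl carbon. For the measured compounds named here, only one step between measured compounds is known, a number 8.1 percentage points higher from compound 1 to compound 2 (within the scatter), and it changes a different group at a different place and stays within the scatter. Nothing measured bears directly on exchanging carboxymethyl for isopropyl, so the expectation rests on little. The expectation is a step of a number 7.5 percentage points lower from compound 3 to compound 4 (within the scatter), a modest fall that may well turn out to be none beyond the scatter. Compound 4 is estimated at 22%, within a range from 8% to 40%.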

Compound 4, a percentage reported as activity, at one dose (the size of the read-out at that dose, not a potency): 9.13%
The estimate for compound 4 lay 12.9 percentage points above the measured number; the range from low to high includes it.
By their numbers in this assay, from the lowest: compounds 4, 1 and 2 (each within the scatter of the next); then compound 3.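

In this assay the exchange of carboxymethyl for isopropyl gives a number 20.4 percentage points lower from compound 3 to compound 4 (beyond the scatter) and is the only single change shown that lies beyond the scatter, so the group on this saturated chain carbon, two bonds along the chain from an amide-type nitrogen and a carbonyl carbon, does matter for the read-out. The exchange replaces a group with one hydrogen-bond donor and one hydrogen-bond acceptor by a group with neither, and here it goes with a weaker effect, though a single pair establishes no rule. Nothing measured here gives the reason for the fall.

The compounds shown leave open whether the carboxylic acid itself counts at this place, since neither a primary amide nor a longer chain ending in a carboxylic acid stands there. They also leave open whether the same exchange would read alike with a benzyl ester in place of the remaining carboxylic acid.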